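Acylated and imine variants of a sulfonamide hexahydroquinoline series

The source may hold more compounds than are shown below. What is called first, only, known or untested is meant among the compounds shown, and "the series" means these compounds.

Measured so far:
compound 1 `N#CC1=C(N)N(c2ccc(S(N)(=O)=O)cc2)C2=C(C(=O)CCC2)C1c1ccc(Cl)cc1Cl` gives 65%
compound 2 `N#CC1=C(NC(=O)C2CC2)N(c2ccc(S(N)(=O)=O)cc2)C2=C(C(=O)CCC2)C1c1ccc(Cl)cc1Cl` gives 40%
compound 3 `Cc1ccc(C(=O)NC2=C(C#N)C(c3ccc(Cl)cc3Cl)C3=C(CCCC3=O)N2c2ccc(S(N)(=O)=O)cc2)cc1` gives 40%

In a functional assay on Ehrlich cells (Mus musculus) for cytotoxicity, read by trypan blue exclusion, with a stated time of 2 h, tested at 50 ug/mL (a higher number here means a stronger effect of the compound at the concentration tested, a lower number a weaker effect), compound 3 stands level with compound 2 at the digits read, and the two together are the lowest of the three numbers. The step of no change at the digits printed from compound 2 to compound 3 (within the scatter) lies within the scatter, so nothing separates them. Compound 1, the free amine, stands highest: the steps of a number 25 percentage points lower from compound 1 to compound 2 (beyond the scatter) and a number 25 percentage points lower from compound 1 to compound 3 (beyond the scatter) are both beyond the scatter and of the same size, so acylation of the amine nitrogen has cost the same amount whether the acyl group is cyclopropylcarbonyl or (4-methylphenyl)carbonyl.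

Compound 4 `CN(C)c1ccc(/C=N/C2=C(C#N)C(c3ccc(Cl)cc3Cl)C3=C(CCCC3=O)N2c2ccc(S(N)(=O)=O)cc2)cc1` is the next member. Against compound 3 the change is a group of 11 heavy atoms (9 carbon, 2 nitrogen; one six-membered aromatic ring of carbon only) in place of a group of 10 heavy atoms (8 carbon, 1 nitrogen, 1 oxygen; one six-membered aromatic ring of carbon only), on a double-bonded ring carbon

Going by the values given here, no measured step swaps an amide for such a group, so the bearing steps are indirect. The two acylation steps were modest and alike, and the swap of the carbonyl substituent gave nothing; the present change keeps the aromatic ring but removes the carbonyl and the amide hydrogen. For compound 4 the step of a number 5 percentage points higher from compound 3 to compound 4 (within the scatter) is expected to stay within the scatter or be at most modest. The value for compound 4 is therefore estimated at 45%, within 25% to 65%.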

Compound 4, a percentage reported as activity, at one concentration (the size of the read-out at that concentration, not a potency): 30%
Beside the measured number, compound 4's estimate is 15 percentage points above it; low and high end bracket the measured number.
By their numbers in this assay, from the lowest: compounds 4, 2 and 3 (each within the scatter of the next); then compound 1.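

In this assay, the imine group on the double-bonded ring carbon gives a number 10 percentage points lower from compound 3 to compound 4 (within the scatter) and a number 10 percentage points lower from compound 2 to compound 4 (within the scatter), so this position takes an aryl imine in place of either amide without a separable change, even though the carbonyl and the amide hydrogen are gone. Against the free amine, the same group gives a number 35 percentage points lower from compound 1 to compound 4 (beyond the scatter), a step printed as large where the two acylation steps were modest; all three substituted compounds now lie beyond the scatter below compound 1, and none of the four goes against this. No measurement at hand accounts for either the fall from the free amine or the sameness of the three substituted compounds.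

From the compounds shown here alone, it remains open whether a group as small as methyl or acetyl on the amine nitrogen would stay with compound 1 or join compounds 2, 3 and 4, and whether an imine carrying a plain phenyl ring, or a carboxylic acid on that ring, would read differently from the dimethylamino-bearing ring of compound 4. Going by these compounds, all these numbers are read at a single concentration, so the order of potency also stays open.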